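Replacing the Dichloropyridyl Group of Compound 1 with Benzyl

The compounds below may be only part of what the source reports. "The series", "measured", "known", "first", "only" and "open" are said of these compounds alone.

Compound 1 `CCOC(=O)c1cnc(-c2cc(Cl)nc(Cl)c2)nc1NN1C(=O)C=C(C)C1=O` was tested in a functional assay on Jurkat cells for inhibition of nuclear factor NF-kappa-B complex (Homo sapiens) (on this read-out higher numbers stand for weaker inhibition and lower numbers for stronger inhibition), where compound 1 gives 2000 nM. Among the two measured compounds this is the highest number. Its nearest neighbour is compound 2 `CCOC(=O)c1cnc(-c2ccc(F)cc2)nc1NN1C(=O)C=C(C)C1=O`, which in this assay gives 700 nM. Among the measured compounds shown here, the only measured step that bears on the new compound is the one made at the same place of the shared core: a 2.9-fold lower number from compound 1 to compound 2 (0.46 log units; beyond the scatter), a modest gain. Compound 3 `CCOC(=O)c1cnc(Cc2ccccc2)nc1NN1C(=O)C=C(C)C1=O` differs from compound 1 at that same place. benzyl in place of 2,6-dichloropyridin-4-yl on an aromatic carbon The group that enters is again a six-membered aromatic ring of carbon only, as in compound 2, but benzyl itself has not been measured, so the direction of its effect is open. For the measured compounds named here, since the single comparable change gave a 2.9-fold lower number from compound 1 to compound 2 (0.46 log units; beyond the scatter), a step of about that size in either direction is plausible for compound 3. The expected step is a 1.3-fold lower number from compound 1 to compound 3 (0.12 log units; within the scatter), kept small because only a 2.9-fold lower number from compound 1 to compound 2 (0.46 log units; beyond the scatter) is available for comparison. The estimate for compound 3 in this assay is 1500 nM, with a likely range from 400 nM to 5000 nM.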

Compound 3, half-maximal inhibitory concentration: 7000 nM
Estimate against measurement, compound 3: 4.7-fold (0.67 log units) below; measured number outside the range, above it.
By their numbers in this assay, from the lowest: compound 2; then compound 1; then compound 3.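

In this assay, this position can lose as well as gain: the change to benzyl gives a 3.5-fold higher number from compound 1 to compound 3 (0.54 log units; beyond the scatter), the opposite direction to the one seen with 4-fluorophenyl. A ring of carbon only is therefore not enough for a lower number here, since benzyl also carries such a ring and the switch from 4-fluorophenyl gives a 10-fold higher number from compound 2 to compound 3 (1.00 log units; beyond the scatter). Compound 1 and compound 2 hold their aromatic ring directly on the shared core, whereas benzyl holds it through a methylene link, but no measurement available here explains why the number rises.

Among the compounds shown here, with only three compounds, the link and the fluorine cannot be told apart, as compound 2 and compound 3 differ in both, and plain phenyl and 4-fluorobenzyl at this position would be the groups to separate them. Going by these compounds, it also remains open how this position responds to groups with no aromatic ring at all, such as a morpholine, a short alkyl chain or a simple amine.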